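The compounds below may be only part of what the source reports. "The series", "measured", "known", "first", "only" and "open" are said of these compounds alone.

In a functional assay on MIA PaCa-2 cells (Homo sapiens) for cytotoxicity, read by MTT assay, with a stated time of 4 h (a lower number here means a stronger inhibitor, a higher number a weaker inhibitor), compound 1 `COC1=CC(=O)c2c(c(COc3c(F)cc(F)cc3F)c(C)n2C)C1=O` gives 427 nM and compound 2 `COC1=CC(=O)c2c(COc3ccc([N+](=O)[O-])cc3)c(C)n(C)c2C1=O` gives 638 nM while compound 3 `COC1=CC(=O)c2c(COc3ccc(C#N)cc3)c(C)n(C)c2C1=O` gives 463 nM and so stands within the usual scatter of both. Compound 4 `COC1=CC(=O)c2c(COc3cccnc3)c(C)n(C)c2C1=O` is still unmeasured. On the shared core it carries pyridin-3-yl in place of 4-cyanophenyl on an oxygen on a saturated carbon. Among the measured compounds shown here, one measured step bears on this: cyano in place of nitro on an aromatic carbon, which gave a 1.4-fold lower number from compound 2 to compound 3 (0.14 log units; within the scatter) and stayed within the scatter. For the measured compounds named here, no measured compound carries pyridin-3-yl, so this swap is untested, and no step beyond the scatter is expected in this assay for it. The expected step is a 1.3-fold higher number from compound 3 to compound 4 (0.11 log units; within the scatter) and nothing larger. For compound 4 the estimated value is 600 nM with a likely range from 250 nM to 1500 nM overall.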

Compound 4, half-maximal inhibitory concentration: 2480 nM
Compound 4: the middle estimate sits 4.1-fold (0.62 log units) below what was measured; measured number above the stated range.
By their numbers in this assay, from the lowest: compounds 1, 3 and 2 (each within the scatter of the next); then compound 4.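

Measured in this assay the group on this oxygen on a saturated carbon can shift the number beyond the scatter: pyridin-3-yl in place of 4-cyanophenyl gives a clear weakening (a 5.4-fold higher number from compound 3 to compound 4 (0.73 log units; beyond the scatter)). Among the compounds shown here, the only earlier step, cyano in place of nitro on the aromatic carbon (a 1.4-fold lower number from compound 2 to compound 3 (0.14 log units; within the scatter)), stayed within the scatter, so it gave no sign that this part of the molecule mattered. Nothing available explains the new step.

Open, from the compounds shown here alone, is whether a plain phenyl group on this oxygen would read like compound 3 or like compound 4, which would separate the part played by the nitrile from that of the ring nitrogen. Also open, going by these compounds, is how an amine or a carboxylic acid on this ring would read.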